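Pyridin-2-yl Replacing Cyclobutyl at the Carbonyl

The compounds below may be only part of what the source reports. "The series", "measured", "known", "first", "only" and "open" are said of these compounds alone.

Compound 1 `O=C(C1CC1)N1CCCn2nc(COc3ccccc3)cc21` gives 61% in a functional assay on HEK293 cells for positive allosteric modulation of metabotropic glutamate receptor 5 (Homo sapiens), read by calcium flux; on this read-out higher numbers stand for larger maximal responses and lower numbers for smaller maximal responses.
Compound 2 `O=C(C1CCC1)N1CCCn2nc(COc3ccccc3)cc21` gives 41% in this assay.
Compound 3 `O=C(c1ccccc1)N1CCCn2nc(COc3ccccc3)cc21` gives 63% in this assay.

All three share one core and differ only in the group attached to the carbonyl carbon. Compound 2 stands lowest of the three: the move from compound 1 to compound 2 (a number 20 percentage points lower from compound 1 to compound 2 (beyond the scatter)) and the move from compound 2 to compound 3 (a number 22 percentage points higher from compound 2 to compound 3 (beyond the scatter)) both lie beyond the scatter, while compound 1 and compound 3 sit within the scatter of each other (a number 2 percentage points higher from compound 1 to compound 3 (within the scatter)).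

Compound 4 `O=C(c1ccccn1)N1CCCn2nc(COc3ccccc3)cc21` is the next step from compound 2: pyridin-2-yl in place of cyclobutyl on a carbonyl carbon. Among the compounds with values here, the step that bears on it most is the one from compound 2 to compound 3, where a six-membered aromatic ring replaced the same cyclobutyl at the same place and the maximal response rose modestly. Compound 4 also brings a six-membered aromatic ring to that carbonyl carbon, so a rise of similar size in this assay is expected, with the step from compound 2 to compound 4 estimated at a number 19 percentage points higher from compound 2 to compound 4 (beyond the scatter). For compound 4 the expected value is 60%, estimated to lie between 45% and 75%.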

Compound 4, largest response reached (reported as percent of maximum), in percent of the reference or control that the assay uses: 44%
The estimate for compound 4 lay 16 percentage points above the measured number, outside the stated range (below it).
By their numbers in this assay, from the lowest: compounds 2 and 4 (each within the scatter of the next); then compounds 1 and 3 (each within the scatter of the next).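

Putting pyridin-2-yl in place of phenyl on the carbonyl carbon lowers the maximal response in this assay (a number 19 percentage points lower from compound 3 to compound 4 (beyond the scatter)), so a six-membered aromatic ring at this place does not by itself carry the higher response. The pyridin-2-yl group instead falls in with cyclobutyl (a number 3 percentage points higher from compound 2 to compound 4 (within the scatter)) and apart from cyclopropyl (a number 17 percentage points lower from compound 1 to compound 4 (beyond the scatter)), which splits the four compounds into two pairs that neither ring size nor aromatic character sorts. No measurement available here accounts for the difference between the phenyl and pyridin-2-yl groups.

Still open, on these data alone, is whether pyridin-3-yl or pyridin-4-yl on the carbonyl carbon would group with compound 3 or with compound 4. Also open, as far as these compounds go, is where a cyclopentyl group would fall, given the gap between the cyclopropyl and cyclobutyl compounds.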